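The compounds below may be only part of what the source reports. "The series", "measured", "known", "first", "only" and "open" are said of these compounds alone.

Measured so far in a functional assay on DU-145 cells (Homo sapiens) for cytotoxicity, read by MTT assay, with a stated time of 48 h (a lower number here means a stronger inhibitor, a higher number a weaker inhibitor), are these compounds:
- compound 1 (`COc1ccc(-c2nc3ccccn3c2C(=O)/C=C\Nc2ccc3[nH]ccc3c2)cc1`) at 11300 nM
- compound 2 (`COc1ccc(-c2nc3ccccn3c2C(=O)/C=C\Nc2ccc3cc[nH]c3c2)cc1`) at 10700 nM
- compound 3 (`COc1ccc(-c2nc3ccccn3c2C(=O)/C=C\Nc2cnc3ccccc3c2)cc1`) at 5280 nM

Of these three, compound 3 has the lowest number. Both a 2.1-fold lower number from compound 1 to compound 3 (0.33 log units; beyond the scatter) and a 2.0-fold lower number from compound 2 to compound 3 (0.31 log units; beyond the scatter) are modest steps beyond the scatter.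

Compound 4 (`COc1ccc(-c2nc3ccccn3c2C(=O)/C=C\Nc2ccc3ncccc3c2)cc1`) differs from compound 3 in one place, on an amine nitrogen whose other neighbours are a double-bonded chain carbon. There, quinolin-6-yl stands in place of quinolin-3-yl (quinolin-6-yl in place of quinolin-3-yl on an amine nitrogen) and the rest of the structure is shared.

Within the data shown here, no measured pair compares two quinolinyl groups. The nearest guide is a 1.1-fold lower number from compound 1 to compound 2 (0.02 log units; within the scatter) for 1H-indol-6-yl in place of 1H-indol-5-yl, a step within the scatter. The two modest steps exchange one kind of group for another, which is not what happens here, so they bear on this change less directly. A single pair is thin support, but no step beyond the scatter is expected in this assay in either direction. The estimated step is a 1.1-fold higher number from compound 3 to compound 4 (0.06 log units; within the scatter) and it is expected to stay within the scatter. Compound 4 is expected at an estimated 6000 nM, with a range of 2500 nM to 13000 nM.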

Compound 4, half-maximal inhibitory concentration: 4720 nM
For compound 4 the middle estimate is 1.3-fold (0.10 log units) above the measured one; low and high end bracket the measured number.
By their numbers in this assay, from the lowest: compounds 4 and 3 (each within the scatter of the next); then compounds 2 and 1 (each within the scatter of the next).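

The exchange of quinolin-3-yl for quinolin-6-yl on the amine nitrogen gives a 1.1-fold lower number from compound 3 to compound 4 (0.05 log units; within the scatter), so in this assay these two quinolinyl groups are not told apart at this position, just as the two indolyl groups were not. Compound 4 also stands apart from the indolyl compounds, with a 2.3-fold lower number from compound 2 to compound 4 (0.36 log units; beyond the scatter) and a 2.4-fold lower number from compound 1 to compound 4 (0.38 log units; beyond the scatter), so the modest gap seen earlier for quinolin-3-yl is not confined to that one quinolinyl group. Nothing available explains why the quinolinyl and indolyl groups differ at this position, or why the two quinolinyl groups do not.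

It remains open whether a single-ring group on this amine nitrogen, such as phenyl or pyridin-3-yl, would stand with the quinolinyl compounds, with the indolyl compounds or apart from both, and whether quinolin-2-yl would match the two quinolinyl groups shown. The compounds shown also leave open whether these modest gaps would hold on other cell lines, since all four values come from a single cell line and a single read-out.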